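The source may report more compounds than this note shows. Statements on the series, on what has been measured and on what is new or still open speak of the compounds shown alone.

In a functional assay on PC-3 cells (Homo sapiens) (a higher number here means a weaker inhibitor of growth, a lower number a stronger inhibitor of growth), compound 1 `O=S(=O)(/C=C/c1ccc(Cl)c(Cl)c1)Cc1ccc(Nc2ncnc3ccccc23)cc1` gives 35000 nM, compound 2 `O=S(=O)(/C=C/c1ccc(F)cc1Cl)Cc1ccc(Nc2ncnc3ccccc23)cc1` gives 100000 nM and compound 3 `O=S(=O)(/C=C/c1ccc(Cl)c(Cl)c1)Cc1ccc(Nc2ncnc3ccc(Br)cc23)cc1` gives 11000 nM, the lowest of the three numbers. Compound 4 `O=S(=O)(/C=C/c1ccc(Cl)cc1Cl)Cc1ccc(Nc2ncnc3ccc(Br)cc23)cc1` carries 2,4-dichlorophenyl in place of 3,4-dichlorophenyl on a double-bonded chain carbon bound to a double-bonded chain carbon. Among the measured compounds shown here, no measured pair shows this exact change. The nearest evidence is a 2.9-fold higher number from compound 1 to compound 2 (0.46 log units; beyond the scatter), where 2-chloro-4-fluorophenyl replaces 3,4-dichlorophenyl. The other measured step, a 3.2-fold lower number from compound 1 to compound 3 (0.50 log units; beyond the scatter), comes from bromo in place of hydrogen on an aromatic carbon, so it bears only on the level of compound 3. The expected step in this assay is modest and toward a higher number: a 2.0-fold higher number from compound 3 to compound 4 (0.30 log units; within the scatter). For compound 4, the estimated value is 22000 nM, with an expected range of 8000 nM to 60000 nM.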

Compound 4, concentration for 50% growth inhibition: 4000 nM
The estimate for compound 4 lay 5.5-fold (0.74 log units) above the measured number; the measured number lies below the stated range.
By their numbers in this assay, from the lowest: compound 4; then compound 3; then compound 1; then compound 2.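

In this assay, 2,4-dichlorophenyl in place of 3,4-dichlorophenyl gives a 2.8-fold lower number from compound 3 to compound 4 (0.44 log units; beyond the scatter), so a change of this group at this position can also lower the number. The earlier replacement by 2-chloro-4-fluorophenyl went the other way (a 2.9-fold higher number from compound 1 to compound 2 (0.46 log units; beyond the scatter)), on the core without bromo. Nothing measured here accounts for this difference in direction. As far as these compounds go, whether the opposite directions follow from the aryl group or from the bromo on the core stays open. So does the reading with an amine or a methoxy group on that phenyl ring.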